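A few compounds are considered here, and "the series" means these few. Any claim that something is new, unique, unknown or untested is made for them only; others in the source may bear on it.

Among the compounds with values here, compound 2 `CC(=O)OC/C(=C\c1ccccc1Br)C(=O)c1ccccc1` is the weaker of the two measured members. In a functional assay on HeLa cells (Homo sapiens) for inhibition, read by sulforhodamine B assay, with a stated time of 48 h (a lower number here means a stronger inhibitor of growth, a higher number a weaker inhibitor of growth), compound 2 gives 20000 nM, the highest number among the two compounds with a result, while compound 1 `CC(=O)OC/C(=C\c1ccc(Cl)cc1)C(=O)c1ccccc1` in this assay gives 3200 nM. Within the data shown here, the one measured step, a 6.3-fold higher number from compound 1 to compound 2 (0.80 log units; beyond the scatter), is the only comparison that speaks to the effect of the halogenated aryl group, and it changes both the halogen and its position at once.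

Compound 3 `CC(=O)OC/C(=C\c1ccccc1F)C(=O)c1ccccc1` keeps the whole of compound 2 except for one substituent: fluoro in place of bromo on an aromatic carbon. Among the measured compounds shown here, no measured pair isolates a change of halogen at this position, so the step from compound 1 to compound 2 bears on it only in an indirect way, showing that the aryl substituent can move this assay by a modest amount. Compound 3 is therefore expected to land near compound 2, with a step of a 1.7-fold lower number from compound 2 to compound 3 (0.22 log units; within the scatter) that may be small or not beyond the scatter. The estimate for compound 3 in this assay is 12000 nM, within a range from 3000 nM to 45000 nM.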

Compound 3, concentration for 50% growth inhibition: 22000 nM
For compound 3 the middle estimate is 1.8-fold (0.26 log units) below the measured one; the range from low to high includes it.
By their numbers in this assay, from the lowest: compound 1; then compounds 2 and 3 (each within the scatter of the next).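

In this assay, fluoro in place of bromo on this aromatic carbon, ortho to a large group, gives a 1.1-fold higher number from compound 2 to compound 3 (0.04 log units; within the scatter), so these two halogens are not told apart here, something the earlier pair could not show because it changed both halogen and position at once. The second new step, a 6.9-fold higher number from compound 1 to compound 3 (0.84 log units; beyond the scatter), runs in the same direction as a 6.3-fold higher number from compound 1 to compound 2 (0.80 log units; beyond the scatter), which means that compound 1 keeps the lower number against both the 2-bromophenyl and the 2-fluorophenyl compound, whichever of these two halogens is present. No measurement available here accounts for these results.

The compounds shown leave open whether the lower number of compound 1 goes with the chloro group itself or with the place where it sits, as the halogen and its position still change together in both steps from compound 1. They also leave open how this assay would respond to a group other than a halogen on this aromatic carbon, such as an amine or a methoxy group.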